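This account rests on a few compounds, and the source may have more. Where it says the series, first, only, none or still open, it means among the compounds named here.

In a functional assay on blood (Platelet, Oryctolagus cuniculus) for inhibition, read by turbidimetry, with a stated time of 2 min (a lower number here means a stronger inhibitor, a higher number a weaker inhibitor), compound 1 (`COc1ccc(S(=O)(=O)N2CCN(c3ccc(C)cc3)CC2)cc1S(=O)(=O)N1CCN(c2ccc(C)cc2)CC1`) reads 680 nM and so holds the higher of the two numbers. Compound 2 (`COc1ccc(S(=O)(=O)N2CCN(Cc3ccccc3)CC2)cc1S(=O)(=O)N1CCN(Cc2ccccc2)CC1`) reads 330 nM and is the stronger inhibitor of the pair, by a gap beyond the usual scatter. Compound 3 (`CCOc1ccc(S(=O)(=O)N2CCN(c3ccc(C)cc3)CC2)cc1S(=O)(=O)N1CCN(c2ccc(C)cc2)CC1`) differs from compound 1 in one place (methyl in place of hydrogen on a saturated chain carbon bound to an oxygen on an aromatic ring): methyl in place of hydrogen on a saturated chain carbon bound to an oxygen on an aromatic ring, which turns methoxy into ethoxy. Among the measured compounds shown here, no measured pair shows this change alone, so the data give no direct size for it. In this assay a step no larger than the scatter is expected, with no firm direction. The estimated change is a 1.1-fold lower number from compound 1 to compound 3 (0.05 log units; within the scatter) and it is expected to stay within the scatter. Compound 3 is expected at 600 nM with an estimated range of 280 nM to 1300 nM as its likely span.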

Compound 3, half-maximal inhibitory concentration: 260 nM
Estimate against measurement, compound 3: 2.3-fold (0.36 log units) above; measured number below the stated range.
By their numbers in this assay, from the lowest: compounds 3 and 2 (each within the scatter of the next); then compound 1.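

Lengthening methoxy to ethoxy gives, in this assay, a 2.6-fold lower number from compound 1 to compound 3 (0.42 log units; beyond the scatter), the first direct reading of this position, and it shows that a single added methyl on the saturated chain carbon bound to an oxygen on an aromatic ring can move the number beyond the scatter. Compound 1 and compound 3 are otherwise identical, so the step belongs to this one change, although it rests on a single pair. No available evidence bears on what lies behind the step.

On these data alone, whether the number falls further with a longer chain such as propoxy or a branched one such as isopropoxy stays open, as does the outcome of putting a hydroxyl or an amine at this place. Also open, as far as these compounds go, is whether ethoxy in place of methoxy would give a like step on compound 2.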